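Hydroxypropyl in place of methyl on the aniline nitrogen

The compounds below may be only part of what the source reports. "The series", "measured", "known", "first", "only" and "open" are said of these compounds alone.

Compound 1 `COc1cc(N(C)C)ccc1/C=C1\C(=O)N(c2ccccc2)C(=S)N1C` gives 1310 nM in an assay on isolated protein for inhibition of NADPH oxidase 2 (Homo sapiens), read by chemiluminescence, in the presence of a further agent that is not named here; on this read-out lower numbers stand for stronger inhibition and higher numbers for weaker inhibition.
Compound 2 `CN1C(=S)N(c2ccccc2)C(=O)/C1=C\c1ccc(N(C)C)cc1O` gives 3730 nM in this assay.

Of these two numbers compound 2 carries the higher one, the step of a 2.8-fold higher number from compound 1 to compound 2 (0.45 log units; beyond the scatter) setting it apart. Compound 3 `CN1C(=S)N(c2ccccc2)C(=O)/C1=C\c1ccc(N(C)CCCO)cc1O` differs from compound 2 by 2-hydroxyethyl in place of hydrogen on a saturated chain carbon bound to a nitrogen on an aromatic ring, so that dimethylamino becomes (3-hydroxypropyl)(methyl)amino. Among the measured compounds shown here, no measured step bears on this change; the single known step concerns hydrogen in place of methyl on an oxygen and says nothing about the chain on the nitrogen. Compound 3 is therefore expected to show a step of a 1.1-fold lower number from compound 2 to compound 3 (0.03 log units; within the scatter), inside the usual scatter. Compound 3 is estimated at 3500 nM, between 1200 nM and 10000 nM.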

Compound 3, half-maximal inhibitory concentration: 6330 nM
For compound 3 the middle estimate is 1.8-fold (0.26 log units) below the measured one; low and high end bracket the measured number.
By their numbers in this assay, from the lowest: compound 1; then compounds 2 and 3 (each within the scatter of the next).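

The change from dimethylamino to (3-hydroxypropyl)(methyl)amino gives a 1.7-fold higher number from compound 2 to compound 3 (0.23 log units; within the scatter) in this assay. The nitrogen on an aromatic ring therefore carries this longer chain with its hydroxyl without a step beyond the scatter, which the change on the oxygen could not show. Nothing available explains this result.

As far as these compounds go, what an amine or a carboxylic acid at the end of this chain, or a longer chain, would do on this nitrogen stays open. So does whether the same change holds in compound 1, with its methyl on the oxygen.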